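The source may hold more compounds than are shown below. What is called first, only, known or untested is meant among the compounds shown, and "the series" means these compounds.

Measured so far:
- compound 1, `CCc1sc(CCc2cc(OCC3(C)CC3)cc(NCc3cc(Cl)cc(NC(=O)OC(C)C)c3)n2)nc1C`, gives 17 nM
- compound 2, `CCc1sc(CCc2cc(OC3CCC3)cc(NCc3cc(Cl)cc(NC(=O)OC(C)C)c3)n2)nc1C`, gives 11 nM
- compound 3, `CCc1sc(CCc2cc(OC3CCCCC3)cc(NCc3cc(Cl)cc(NC(=O)OC(C)C)c3)n2)nc1C`, gives 29 nM

All three share one core and differ only in the group carried on an oxygen on an aromatic ring. In an assay on cells for binding affinity to Neuropeptide Y receptor type 1 (Homo sapiens) (a lower number here means a stronger inhibitor, a higher number a weaker inhibitor), compound 3 holds the highest of the three numbers. Its distance to compound 1 is small, a 1.7-fold higher number from compound 1 to compound 3 (0.23 log units; within the scatter), while its distance to compound 2 is larger, a 2.6-fold higher number from compound 2 to compound 3 (0.42 log units; beyond the scatter). The remaining pair, compound 1 and compound 2, lie close together: a 1.5-fold lower number from compound 1 to compound 2 (0.19 log units; within the scatter).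

Compound 4, `CCc1sc(CCc2cc(OCCCc3cccnc3)cc(NCc3cc(Cl)cc(NC(=O)OC(C)C)c3)n2)nc1C`, has not yet been measured. It differs from compound 3 in one place: 3-(pyridin-3-yl)propyl in place of cyclohexyl on an oxygen on an aromatic ring. All three measured steps also exchange the group on that same oxygen, and each of them was modest at most, so they suggest that this position tolerates change without large swings. None of them, however, introduces an aromatic ring or a hetero atom there, so they bear on the new change only loosely. On that basis a small step is expected in this assay, a 1.2-fold lower number from compound 3 to compound 4 (0.06 log units; within the scatter), with direction uncertain. Compound 4 is therefore estimated at 25 nM, with a range from 8 nM to 80 nM.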

Compound 4, half-maximal inhibitory concentration: 6.5 nM
Compound 4: middle estimate off by 3.8-fold (0.59 log units), on the high side; the measured number lies below the stated range.
By their numbers in this assay, from the lowest: compounds 4, 2, 1 and 3 (each within the scatter of the next, the first and the last beyond it).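

In this assay the group on the oxygen on an aromatic ring can carry an aromatic ring with a hetero atom: 3-(pyridin-3-yl)propyl, with 9 heavy atoms against the 6 of cyclohexyl, gives a 4.5-fold lower number from compound 3 to compound 4 (0.65 log units; beyond the scatter), and the exchange read from the other side of the series gives a 2.6-fold lower number from compound 1 to compound 4 (0.42 log units; beyond the scatter). The earlier step from cyclobutyl to cyclohexyl had raised the number with the larger group, but compound 4 goes against any reading of that step as a rule about size, for even with the largest group shown it stands level with the cyclobutyl compound, at a 1.7-fold lower number from compound 2 to compound 4 (0.23 log units; within the scatter). Nothing measured here accounts for these steps.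

The compounds shown leave open whether the ring nitrogen matters or any aromatic ring on this chain would serve, which a 3-phenylpropyl group on the same oxygen would test, and whether the length of the chain counts, which 2-(pyridin-3-yl)ethyl would test. They also leave open how the place of the nitrogen in the ring bears on the number, as in 3-(pyridin-4-yl)propyl, and whether a simple amine at the end of the chain could take the place of the ring.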